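This account rests on a few compounds, and the source may have more. Where it says the series, first, only, none or still open, it means among the compounds named here.

Compound 3 `CCCCC(O)C1=CC(=O)c2c(OC)ccc(OC)c2C1=O` was tested in a functional assay on L1210 cells (Mus musculus) for cytotoxicity (on this read-out lower numbers stand for an effect already at smaller amounts and higher numbers for an effect only at larger amounts of compound), and gave 0.412 ug/mL. Compound 1 `CCC(O)C1=CC(=O)c2c(OC)ccc(OC)c2C1=O` gives 0.516 ug/mL in this assay, and compound 2 `COc1ccc(OC)c2c1C(=O)C=C(CO)C2=O` gives 0.524 ug/mL; compound 3 sits within the scatter of both, with a 1.3-fold lower number from compound 1 to compound 3 (0.10 log units; within the scatter) and a 1.3-fold lower number from compound 2 to compound 3 (0.10 log units; within the scatter). Compound 4 `COc1ccc(OC)c2c1C(=O)C=C(C(C)O)C2=O` differs from compound 3 by hydrogen in place of propyl on a saturated chain carbon, two bonds along the chain from a double-bonded ring carbon and an oxygen on a saturated carbon. Shortening this side chain has so far changed little: a 1.0-fold higher number from compound 1 to compound 2 (0.01 log units; within the scatter), and the two steps toward compound 3 were also within the scatter. Since compound 4 carries a chain between those of compound 2 and compound 1, the step is expected to be a 1.2-fold higher number from compound 3 to compound 4 (0.08 log units; within the scatter), no more than the scatter. Compound 4 is therefore estimated at 0.5 ug/mL, with a range from 0.25 ug/mL to 1 ug/mL.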

Compound 4, concentration for half-maximal effect: 0.487 ug/mL
Estimate against measurement, compound 4: 1.0-fold (0.01 log units) above; low and high end bracket the measured number.
By their numbers in this assay, from the lowest: compounds 3, 4, 1 and 2 (each within the scatter of the next).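

In this assay cutting 1-hydroxypentyl down to 1-hydroxyethyl gives a 1.2-fold higher number from compound 3 to compound 4 (0.07 log units; within the scatter) and so stays within the scatter. The same holds against the two remaining side chains, with a 1.1-fold lower number from compound 2 to compound 4 (0.03 log units; within the scatter) and a 1.1-fold lower number from compound 1 to compound 4 (0.03 log units; within the scatter) as the steps. All four chains shown at this position therefore read alike, and no trend with chain length appears among them. From the compounds shown here alone, whether an amine, a carboxylic acid or a much longer chain here would give a different number stays open. Nothing available explains why these chains read alike.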